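Adding 2-chlorobenzyl on a sulfur of compound 1

The source may hold more compounds than are shown below. What is called first, only, known or untested is meant among the compounds shown, and "the series" means these compounds.

- compound 1 `Sc1nnc(-c2ccc3c(c2)OCCO3)n1-c1ccccc1` gives 60000 nM
- compound 2 `c1ccc(CSc2nnc(-c3ccc4c(c3)OCCO4)n2-c2ccccc2)cc1` gives 5960 nM
- compound 3 `O=[N+]([O-])c1ccc(CSc2nnc(-c3ccc4c(c3)OCCO4)n2-c2ccccc2)cc1` gives 13800 nM

In a functional assay on HepG2 cells (Homo sapiens) for antiproliferative activity, read by MTT assay, with a stated time of 24 h (on this read-out lower numbers stand for stronger inhibition and higher numbers for weaker inhibition), compound 1 has the highest of the three numbers (60000 nM), which makes it the weakest of the three. Compound 4 `Clc1ccccc1CSc1nnc(-c2ccc3c(c2)OCCO3)n1-c1ccccc1` differs from it by one change (2-chlorobenzyl in place of hydrogen on a sulfur), namely 2-chlorobenzyl in place of hydrogen on a sulfur.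

Among the measured compounds shown here, two measured steps bear directly on this change. Benzyl in place of hydrogen on a sulfur gives a modest step (a 10-fold lower number from compound 1 to compound 2 (1.00 log units; beyond the scatter)), and 4-nitrobenzyl in the same place gives a smaller one (a 4.3-fold lower number from compound 1 to compound 3 (0.64 log units; beyond the scatter)). A third step (a 2.3-fold higher number from compound 2 to compound 3 (0.36 log units; beyond the scatter)) separates those two and shows that nitro in place of hydrogen on an aromatic carbon moves the number beyond the scatter. For the measured compounds named here, no compound carrying chlorine has been measured, so the contribution of the chlorine remains open.

A modest step to a lower number is expected, resting on compound 2 (5960 nM) and compound 3 (13800 nM). The expected step (a 7.5-fold lower number from compound 1 to compound 4 (0.88 log units; beyond the scatter)) falls between the two measured ones. The estimate for compound 4 is 8000 nM with an expected range from 3000 nM to 20000 nM until a measurement is available.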

Compound 4, half-maximal inhibitory concentration: 970 nM
Beside the measured number, compound 4's estimate is 8.2-fold (0.92 log units) above it; measured number below the stated range.
By their numbers in this assay, from the lowest: compound 4; then compound 2; then compound 3; then compound 1.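

In this assay, a 62-fold lower number from compound 1 to compound 4 (1.79 log units; beyond the scatter) is a large step, whereas the steps from compound 1 to compound 2 and to compound 3 were modest, so the group on this sulfur can move the number further than those two compounds showed. A chlorine on the benzyl ring gives a 6.1-fold lower number from compound 2 to compound 4 (0.79 log units; beyond the scatter), while nitro gave a 2.3-fold higher number from compound 2 to compound 3 (0.36 log units; beyond the scatter), so among these compounds a substituent on the benzyl ring can shift the number in either direction, and the change from 4-nitrophenyl to 2-chlorophenyl accordingly gives a 14-fold lower number from compound 3 to compound 4 (1.15 log units; beyond the scatter). Nothing measured here accounts for these steps.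

Compound 3 and compound 4 differ both in the substituent and in where it sits on the ring, so the compounds shown cannot say whether the gain belongs to the chlorine itself or to its place. Also open, as far as these compounds go, is how an amine or a carboxylic acid on that ring, or a longer chain on the sulfur, would compare with the 2-chlorobenzyl of compound 4.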